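A Trifluoromethoxy Variant and an Unchanged Cytotoxicity Limit

The source may report more compounds than this note shows. Statements on the series, on what has been measured and on what is new or still open speak of the compounds shown alone.

Compound 2 `O=[N+]([O-])c1cn2c(n1)OC[C@@H](OCc1cc(-c3ccc(C(F)(F)F)cc3)no1)C2` stands only at a limit in an ADME assay on Vero cells (Chlorocebus sabaeus) for cytotoxicity, with a stated time of 72 h; on this read-out lower numbers stand for stronger inhibition and higher numbers for weaker inhibition: in this assay compound 2 gives > 128000 nM, a limit of the assay rather than a number. Compound 1 `O=[N+]([O-])c1cn2c(n1)OC[C@@H](OCc1cccc(-c3ccc(F)cc3)c1)C2` likewise reaches only a limit, giving in this assay > 128000 nM. Both values shown sit at the limit of > 128000 nM in this assay, at which 2 of the 2 values shown sit. Compound 3 `O=[N+]([O-])c1cn2c(n1)OC[C@@H](OCc1cc(-c3ccc(OC(F)(F)F)cc3)no1)C2` is not yet measured; it carries trifluoromethoxy in place of trifluoromethyl on an aromatic carbon. Among the compounds with values here, with no measured step available, the expected step in this assay is a step that the limit leaves unreadable from compound 2 to compound 3, nothing beyond the scatter. Compound 3 is estimated at 150000 nM, within 80000 nM to 300000 nM, most probably reported again as a limit.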

Compound 3, half-maximal inhibitory concentration: > 128000 nM
Compound 3: only a limit was reported (the forecaster's own chance of this, stated with the estimate: 85%); the middle value lies beyond the limit too.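

Within the data shown here, with compound 3 also reported only as a limit in this assay, no step from compound 2 to compound 3 can be read: the limit of > 128000 nM in this assay, at which 3 of the 3 values shown sit. The compounds shown leave open where the true values of all three lie in this assay.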